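One Methoxy Group Less: Expectation for Compound 4

This account rests on a few compounds, and the source may have more. Where it says the series, first, only, none or still open, it means among the compounds named here.

Compound 1 `COc1cc(-c2cc(/C=C/C(=O)c3ccc(N)cc3)[nH]n2)cc(OC)c1OC`: > 100000 nM in a functional assay on T47D cells (Homo sapiens) for inhibition, read by sulforhodamine B assay, with a stated time of 48 h; a lower number here means that less compound is tolerated, a higher number that more compound is tolerated
Compound 2 `COc1ccc(-c2cc(/C=C/C(=O)c3ccc(OC)c(OC)c3)[nH]n2)cc1`: 24900 nM
Compound 3 `COc1cc(-c2cc(/C=C/C(=O)c3ccc(Cl)c(Cl)c3)[nH]n2)cc(OC)c1OC`: > 100000 nM

Compound 1 stands at a limit of this assay rather than at a number. Compound 3 also returns only a limit. Among the compounds with values here, the single measured step, a step that the two limits leave unreadable from compound 1 to compound 3, is therefore unreadable, because of the limit of > 100000 nM in this assay, at which 2 of the 3 values shown sit. Within the data shown here, compound 2 gives 24900 nM, the one number among the three, but no measured step connects it to compound 1.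

Compound 4 `COc1ccc(-c2cc(/C=C/C(=O)c3ccc(N)cc3)[nH]n2)cc1OC` differs from compound 1 in one place: hydrogen in place of methoxy on an aromatic carbon. Among the measured compounds shown here, none of the measured steps touches this kind of change, and the starting point, compound 1, is itself only a limit, so the data give no footing for a direction. The step from compound 1 to compound 4 is expected to be an at least 1.4-fold lower number from compound 1 to compound 4 (0.15 log units; that floor lies within the scatter), which is no more than a guess anchored at the limit. Compound 4 is estimated at 70000 nM, in a range from 15000 nM to 300000 nM, with a considerable chance that the assay again reports only a limit.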

Compound 4, concentration lethal to 50% of the cells: > 100000 nM
Compound 4 ended at the assay's limit; the forecaster's own chance of this, stated with the estimate: 55%; middle value at least 1.4-fold (0.15 log units) away from the limit.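

The step from compound 1 to compound 4 cannot be read because both compounds return only a limit: the limit of > 100000 nM in this assay, at which 3 of the 4 values shown sit. The compounds shown leave open whether hydrogen in place of methoxy on an aromatic carbon changes the value in either direction.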